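Nitro removal in two coumarin amide cores

The compounds below may be only part of what the source reports. "The series", "measured", "known", "first", "only" and "open" are said of these compounds alone.

The series comprises compound 1 `CCOc1ccc2nc(Cl)c(/C=N/NC(=O)c3cc4cc([N+](=O)[O-])ccc4oc3=O)cc2c1`, compound 2 `CCOc1ccc2nc(Cl)c(/C=N/NC(=O)c3cc4ccccc4oc3=O)cc2c1`, compound 3 `CCOc1ccc(NC(=O)c2cc3cc([N+](=O)[O-])ccc3oc2=O)cc1` and compound 4 `CCOc1ccc(NC(=O)c2cc3ccccc3oc2=O)cc1`. In a functional assay on CCRF-CEM cells (Homo sapiens) for antiproliferative activity, read by fluorescence and resazurin assay, with a stated time of 48 h (on this read-out lower numbers stand for stronger inhibition and higher numbers for weaker inhibition), compound 1 gives 15700 nM and compound 2 gives 6320 nM. The change between them is hydrogen in place of nitro on an aromatic carbon, and the step it made is a 2.5-fold lower number from compound 1 to compound 2 (0.40 log units; beyond the scatter). Compound 3 carries a different core; how the core of compound 3 differs from that of compound 1 is not broken down here. In this assay compound 3 gives 13200 nM, which lies within the scatter of compound 1 and beyond the scatter of compound 2. Compound 4 is unmeasured and differs from compound 3 by hydrogen in place of nitro on an aromatic carbon, the same change as from compound 1 to compound 2, at a place described in identical terms. For compound 4 a step of a 2.4-fold lower number from compound 3 to compound 4 (0.38 log units; beyond the scatter) is expected, resting on compound 1 and compound 2 showing a 2.5-fold lower number from compound 1 to compound 2 (0.40 log units; beyond the scatter) and on the value of compound 3, 13200 nM, which lies within the scatter of compound 1. The estimate for compound 4 in this assay is 5500 nM, with a range from 2500 nM to 12000 nM.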

Compound 4, half-maximal inhibitory concentration: 17900 nM
Compound 4: middle estimate off by 3.3-fold (0.51 log units), on the low side; measured number above the stated range.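

In this assay, going by these compounds alone, hydrogen in place of nitro gives a 1.4-fold higher number from compound 3 to compound 4 (0.13 log units; within the scatter), so on this core the change produces no step that stands clear of the scatter. Set beside the earlier step, the change does not carry over in size from the core of compound 1 to the core of compound 3: the same change on two cores in this assay, a 2.5-fold lower number (0.40 log units; beyond the scatter) from compound 1 to compound 2 and a 1.4-fold higher number (0.13 log units; within the scatter) from compound 3 to compound 4, 3.4-fold (0.53 log units) apart, beyond the scatter of two such steps. For these two pairs, the outcome of the change depends on the core, but the data do not show which part of the core is responsible, and two pairs set no rule for any other core in the series.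

The compounds shown leave open whether an amine or a carboxylic acid on the same aromatic carbon would also give different steps on the two cores. They also leave open whether a core carrying only part of the difference between compound 1 and compound 3 would follow the larger step or the one within the scatter.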